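A few compounds are considered here, and "the series" means these few. Any claim that something is new, unique, unknown or untested is made for them only; others in the source may bear on it.

Three close analogues built on one shared core have been measured in a functional assay on A549 cells (Homo sapiens) for inhibition, read by MTT assay, with a stated time of 48 h; on this read-out lower numbers stand for stronger inhibition and higher numbers for weaker inhibition. Compound 1 `COc1cc2ccc(=O)oc2cc1OCCCOc1no[n+]([O-])c1S(=O)(=O)c1ccccc1` gives 5450 nM, compound 2 `COc1cc2cc(NC(C)=O)c(=O)oc2cc1OCCOc1no[n+]([O-])c1S(=O)(=O)c1ccccc1` gives 8790 nM, and compound 3 `COc1cc2cc(NC(C)=O)c(=O)oc2cc1OCCCOc1no[n+]([O-])c1S(=O)(=O)c1ccccc1` gives 9810 nM. Going by the values given here, the one single-point step among them, a 1.8-fold higher number from compound 1 to compound 3 (0.26 log units; within the scatter), is within the scatter, so compound 3 sits together with the other two rather than apart from them. Compound 4 `COc1cc2cc(N)c(=O)oc2cc1OCCCOc1no[n+]([O-])c1S(=O)(=O)c1ccccc1` differs from compound 3 by hydrogen in place of acetyl on a nitrogen on an aromatic ring. Among the compounds with values here, no measured step removes an acetyl from this nitrogen; the nearest guide is a 1.8-fold higher number from compound 1 to compound 3 (0.26 log units; within the scatter), which stays within the scatter even though the whole acetamido group is gained there. On that basis the step from compound 3 to compound 4 is expected to be a 1.2-fold lower number from compound 3 to compound 4 (0.09 log units; within the scatter), not beyond the scatter in either direction. Compound 4 is therefore estimated at 8000 nM, with a range from 3500 nM to 18000 nM.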

Compound 4, half-maximal inhibitory concentration: 4180 nM
Compound 4: middle estimate off by 1.9-fold (0.28 log units), on the high side; the measured number falls inside the stated range.
By their numbers in this assay, from the lowest: compounds 4, 1, 2 and 3 (each within the scatter of the next, the first and the last beyond it).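

In this assay, going by these compounds alone, taking the acetyl off the nitrogen on the aromatic ring gives the first step here to pass the scatter, though only a modest one: a 2.3-fold lower number from compound 3 to compound 4 (0.37 log units; beyond the scatter). Set against hydrogen on the same aromatic carbon, the amino group stays within the scatter, with a 1.3-fold lower number from compound 1 to compound 4 (0.12 log units; within the scatter). This position therefore responds to the acetyl on this nitrogen, by a small margin, and not measurably to the amino group itself. From the compounds shown here alone, what a methylamino group or a longer acyl chain on this nitrogen would give remains open. No available evidence accounts for the difference between acetamido and amino.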